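Diaminoquinoxaline series: benzylamine aryl swap in HOP-62 growth assay

The source may hold more compounds than are shown below. What is called first, only, known or untested is meant among the compounds shown, and "the series" means these compounds.

Measured so far:
compound 1 `Nc1cc(N)c2nc(-c3ccccc3)c(NCc3ccc(Cl)c(Cl)c3)nc2c1` gives 31600 nM
compound 2 `CCOC(=O)[C@H](CCC(=O)O)NC(=O)c1ccc(Sc2nc3cc(N)cc(N)c3nc2-c2ccccc2)cc1` gives 85100 nM
compound 3 `Nc1cc(N)c2nc(-c3ccccc3)c(Sc3ccc(Cl)c(Cl)c3)nc2c1` gives 77600 nM

All three numbers come from a functional assay on HOP-62 cells (Homo sapiens) for inhibition, read by sulforhodamine B assay, with a stated time of 48 h; on this read-out lower numbers stand for stronger inhibition of growth and higher numbers for weaker inhibition of growth. Compound 1 has the lowest number of the three; the nearest is compound 3, whose number is higher by a margin beyond the scatter, and compound 2 sits a little further out, again beyond the scatter. Within the data shown here, no pair among the measured compounds differs in only one place, so no single step can be read directly from them.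

Compound 4 `COc1ccc(CNc2nc3cc(N)cc(N)c3nc2-c2ccccc2)cc1OC` is the next compound to go into this assay. Relative to compound 1 it differs as follows: 3,4-dimethoxyphenyl in place of 3,4-dichlorophenyl on a saturated chain carbon bound to a nitrogen on an aromatic ring The shared core and the link through the saturated chain carbon bound to a nitrogen on the aromatic ring stay as they are in compound 1.

Among the measured compounds shown here, with no comparable step among the measured compounds, the expected step from compound 1 to compound 4 is a 1.3-fold higher number from compound 1 to compound 4 (0.10 log units; within the scatter), which is taken to lie within the scatter, perhaps leaning toward a weaker inhibition of growth. Compound 4 is therefore expected to give about 40000 nM in this assay, within a range of 15000 nM to 110000 nM.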

Compound 4, concentration for total growth inhibition: 34700 nM
The estimate for compound 4 lay 1.2-fold (0.06 log units) above the measured number; the measured number falls inside the stated range.
By their numbers in this assay, from the lowest: compounds 1 and 4 (each within the scatter of the next); then compounds 3 and 2 (each within the scatter of the next).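

In this assay, the series now has its first step that changes one place only: a 1.1-fold higher number from compound 1 to compound 4 (0.04 log units; within the scatter), and this step lies within the scatter. On a saturated chain carbon bound to a nitrogen on an aromatic ring, 3,4-dimethoxyphenyl and 3,4-dichlorophenyl therefore cannot be told apart on this read-out, even though the entering group carries hydrogen-bond acceptors and the leaving group has none. Nothing available explains why the two groups read alike.

Both groups compared here are substituted phenyl rings on the same link, so this one pair says nothing about how far the position tolerates change in general. Going by these compounds, it remains open whether a carboxylic acid or a tertiary amine on the phenyl ring, or a longer chain between the ring and the nitrogen, would move the number beyond the scatter in either direction in this assay, and whether the match between these two groups would hold in other cell lines.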